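A New Group on the Carbonyl of Compound 2

This account rests on a few compounds, and the source may have more. Where it says the series, first, only, none or still open, it means among the compounds named here.

For the measured compounds named here, in a functional assay on PC-3 cells (Homo sapiens) for antiproliferative activity, read by MTT assay, with a stated time of 72 h (a higher number here means a weaker inhibitor, a lower number a stronger inhibitor), compound 2 (`CCn1cc(C(CC)(CC)c2ccc(C#CC(O)(CC)CC)c(C)c2)cc1C(=O)OCCO`) gives 11400 nM as the only actual number so far. Compound 1 (`CCn1c(C(=O)NCCCO)ccc1C(CC)(CC)c1ccc(C#CC(O)(CC)CC)c(C)c1`) gives > 50000 nM and this is a limit of the assay, not a number. Compound 2 therefore stands alone as a measured value, with nothing yet to rank it against.

Compound 3 (`CCn1cc(C(CC)(CC)c2ccc(C#CC(O)(CC)CC)c(C)c2)cc1C(=O)N[C@@H](C(=O)O)C(C)C`) differs from compound 2 in one place ((1-carboxy-2-methylpropyl)amino in place of 2-hydroxyethoxy on a carbonyl carbon) with (1-carboxy-2-methylpropyl)amino in place of 2-hydroxyethoxy on a carbonyl carbon. Going by the values given here, no measured step exists to size this change. Among the compounds with values here, the sole guide is compound 1, whose carbonyl carbon also bears an amino group and which sits at the limit of > 50000 nM in this assay, at which 1 of the 2 values shown sits, as its reading. On that slender basis a modest move toward weaker inhibition is expected, and a reading that reaches the limit would be no surprise. The expected step is a 2.2-fold higher number from compound 2 to compound 3 (0.34 log units; beyond the scatter) in the weaker direction. For compound 3 the estimated value is 25000 nM within an expected range of 8000 nM to 50000 nM in this assay once it is measured.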

Compound 3, half-maximal inhibitory concentration: 10300 nM
Compound 3: middle estimate off by 2.4-fold (0.39 log units), on the high side; the measured number falls inside the stated range.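

For the compounds shown here, at the carbonyl carbon, putting (1-carboxy-2-methylpropyl)amino in place of 2-hydroxyethoxy gives a 1.1-fold lower number from compound 2 to compound 3 (0.04 log units; within the scatter) in this assay, the first step that can be read at this position. Although 4 heavy atoms leave and 8 enter, along with 1 defined stereocentre, the two readings cannot be told apart, and compound 3 shows that a carbonyl carbon bearing this amino group can still give a measured number on these cells. Compound 1 remains the one compound whose reading is a limit of the assay and not a number: the limit of > 50000 nM in this assay, at which 1 of the 3 values shown sits.

Going by these compounds alone, the single step does not show whether the carboxylic acid, the isopropyl branch or the amide nitrogen of the new group matters on its own, or whether the opposite stereocentre would read the same, and it gives no cause for the match between the two readings. Nor can it be told how a plain dimethylamino group or a morpholine on the same carbonyl carbon would read in this assay, as the compounds shown offer no step toward either.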